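Methoxy removal on the shared core: expected metabolic stability

The compounds below may be only part of what the source reports. "The series", "measured", "known", "first", "only" and "open" are said of these compounds alone.

Two compounds of this series have been run in an ADME assay on liver for metabolic stability, with Liver microsome (Homo sapiens) as the target, read by LC-MS, using microsomes and NADPH, with a stated time of 45 min, tested at 3 uM; a higher number here means faster removal of the compound, a lower number slower removal. Compound 1 `COc1ccc2c(=O)c(C)c(-c3cncc(-c4ccc(Cl)c(Cl)c4)c3)[nH]c2c1` gives 14 uL/min in this assay. Compound 2 `COc1ccc2c(=O)c(C)c(-c3cncc(-c4ccc(OC(F)(F)F)cc4)c3)[nH]c2c1` gives 25.9 uL/min in this assay; the gap between compound 1 and compound 2 falls within the usual scatter, so the two are not separated by these numbers, and compound 1 simply sits at the smaller of the two values recorded so far.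

Compound 3 `Cc1c(-c2cncc(-c3ccc(Cl)c(Cl)c3)c2)[nH]c2ccccc2c1=O` keeps the core of compound 1 and its pendant rings and differs in a single place: hydrogen in place of methoxy on an aromatic carbon. Among the compounds with values here, no step between measured compounds covers this change, so nothing in the data so far shows how it moves the number in this assay. The expectation is a small step in this assay, from compound 1 to compound 3, toward slower removal or none beyond the scatter, as a 1.2-fold lower number from compound 1 to compound 3 (0.07 log units; within the scatter) expresses.

Compound 3 is therefore estimated at 12 uL/min in this assay, with a range from 6 uL/min to 25 uL/min.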

Compound 3, intrinsic clearance in a liver preparation (reported as CLH), per the amount of preparation that the assay uses: 5.6 uL/min
For compound 3 the middle estimate is 2.1-fold (0.33 log units) above the measured one; the whole stated range lies above it.
By their numbers in this assay, from the lowest: compound 3; then compounds 1 and 2 (each within the scatter of the next).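

In this assay, hydrogen in place of methoxy on an aromatic carbon of the shared core gives a 2.5-fold lower number from compound 1 to compound 3 (0.40 log units; beyond the scatter), a modest step but one beyond the usual scatter. Within the data shown here, this is the first step that can be read at this position, and with the pendant rings of compound 1 held unchanged, it shows that the number responds to what sits on this aromatic carbon, with the methoxy-bearing compound the faster removed of the pair. Nothing at hand bears on why the number moves, so the step is tied to the change itself and to no mechanism.

The compounds shown cover only methoxy and hydrogen at this place, so the response to a fluorine atom, a hydroxyl, an ethoxy chain or an amine on the same aromatic carbon remains open. Also open, on these data alone, is whether the same exchange on the core carrying the trifluoromethoxy pendant ring of compound 2 gives a step of like direction and size, since a single pair cannot show whether the change carries over to other pendant rings.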